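The source may report more compounds than this note shows. Statements on the series, on what has been measured and on what is new or still open speak of the compounds shown alone.

Three compounds share one core and differ only in the group on the sulfonyl sulfur. Compound 1 `COc1cc2nc(N3CCN(S(=O)(=O)c4ccc(Cl)cc4)CC3)nc(N)c2cc1OC` carries a 4-chlorophenyl there, compound 2 `COc1cc2nc(N3CCN(S(=O)(=O)c4ccc(Cl)s4)CC3)nc(N)c2cc1OC` a 5-chlorothiophen-2-yl, and compound 3 `COc1cc2nc(N3CCN(S(=O)(=O)c4ccc([N+](=O)[O-])cc4)CC3)nc(N)c2cc1OC` a 4-nitrophenyl. In a functional assay on PC-3 cells (Homo sapiens) for inhibition (a lower number here means a stronger inhibitor, a higher number a weaker inhibitor), compound 1 gives 23000 nM; in this assay compound 2 gives 25000 nM, and in this assay compound 3 gives 36000 nM. Compound 1 thus holds the smallest of the three numbers, yet neither companion is separated from it by more than the usual scatter: a 1.1-fold higher number from compound 1 to compound 2 (0.04 log units; within the scatter) and a 1.6-fold higher number from compound 1 to compound 3 (0.19 log units; within the scatter).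

Compound 4 `COc1cc2nc(N3CCN(S(=O)(=O)c4ccc(OC(F)(F)F)cc4)CC3)nc(N)c2cc1OC` differs from compound 1 in one place: trifluoromethoxy in place of chloro on an aromatic carbon. Among the compounds with values here, the step that bears most directly on this change is the one from compound 1 to compound 3, where the chloro on the same aromatic carbon was exchanged for nitro and the number moved by a 1.6-fold higher number from compound 1 to compound 3 (0.19 log units; within the scatter), within the scatter. The swap of the whole ring, a 1.1-fold higher number from compound 1 to compound 2 (0.04 log units; within the scatter), was likewise within the scatter. Within the data shown here, nothing measured so far suggests that replacing the group on that carbon shifts this assay beyond its noise, so compound 4 is expected to land near compound 1, with a 1.1-fold higher number from compound 1 to compound 4 (0.04 log units; within the scatter). The estimate for compound 4 is 25000 nM, with a range from 10000 nM to 60000 nM.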

Compound 4, half-maximal inhibitory concentration: 25000 nM
For compound 4 middle estimate and measured number coincide at the digits printed; the measured number falls inside the stated range.
By their numbers in this assay, from the lowest: compounds 1, 2, 4 and 3 (each within the scatter of the next).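

Trifluoromethoxy is a larger group than chloro by heavy-atom count and adds a hydrogen-bond acceptor, yet in this assay this exchange gives a 1.1-fold higher number from compound 1 to compound 4 (0.04 log units; within the scatter). The result also stays within the scatter against the other two groups, with a 1.4-fold lower number from compound 3 to compound 4 (0.16 log units; within the scatter) and, for the exchange of the whole aryl group on the sulfonyl sulfur, no change at the digits printed from compound 2 to compound 4 (within the scatter). All four compounds now lie within the scatter of one another, so chloro, nitro and trifluoromethoxy on this aromatic carbon cannot be told apart here, and no measurement at hand offers an explanation for this flat picture.

The compounds shown leave open whether any group on this carbon can move the number beyond the scatter, and an amine, a carboxylic acid or a longer chain in that place would put this to the test. They also leave open whether a change to the shared core, rather than to the group on the sulfonyl sulfur, would shift the number in this assay.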